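The compounds below may be only part of what the source reports. "The series", "measured", "known", "first", "only" and "open" are said of these compounds alone.

Compound 3 `Cc1noc(-c2cccc(NC(=O)N3CCC(Oc4ccccc4Cl)CC3)c2)n1` stands at 8 nM in an assay on isolated protein for inhibition of acyl-CoA desaturase 1 (Mus musculus) (on this read-out higher numbers stand for weaker inhibition and lower numbers for stronger inhibition), the lowest of the two numbers available; compound 1 `CNC(=O)c1cccc(NC(=O)N2CCC(Oc3ccccc3)CC2)c1` gives 370 nM in this assay. Compound 2 `CNC(=O)c1cccc(NC(=O)N2CCC(Oc3cc(F)ccc3Cl)CC2)c1` is reported only as a limit in this assay, < 4 nM, and so carries no number to rank (the limit of < 4 nM in this assay, at which 1 of the 3 values shown sits). The step under consideration leads to compound 4 `CC(C)NC(=O)c1cccc(NC(=O)N2CCC(Oc3ccccc3Cl)CC2)c1`, which carries isopropylcarbamoyl in place of 3-methyl-1,2,4-oxadiazol-5-yl on an aromatic carbon. Within the data shown here, the one step measured with a number at each end, an at least 92-fold lower number from compound 1 to compound 2 (1.96 log units; beyond the scatter), is large, but it alters the aryl group on the oxygen and leaves the carbamoyl untouched, so it does not speak directly to the present change. Among the measured compounds shown here, compound 2 shows that a methylcarbamoyl group together with a substituted aryl ether is compatible with strong inhibition, while compound 3 shows the same for the oxadiazole with a chlorophenyl ether; no measured step compares the two groups. With no direct evidence on the carbamoyl-for-oxadiazole swap, no step beyond the scatter is expected for compound 4, and the estimate is no change at the digits printed from compound 3 to compound 4 (within the scatter). Compound 4 is therefore estimated at 8 nM in this assay, within 2 nM to 30 nM.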

Compound 4, half-maximal inhibitory concentration: 810 nM
Estimate against measurement, compound 4: 100-fold (2.01 log units) below; the measured number lies above the stated range.
By their numbers in this assay, from the lowest: compound 3; then compound 1; then compound 4. At a limit, below all of these: compound 2.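

In this assay, the group on an aromatic carbon, meta to a large group, proves far from interchangeable within the 2-chlorophenyl ether pair: isopropylcarbamoyl in place of 3-methyl-1,2,4-oxadiazol-5-yl gives a 100-fold higher number from compound 3 to compound 4 (2.01 log units; beyond the scatter). Among these compounds, the earlier compounds offered no step at this place, so this is the first reading in which the place itself moves the number while the aryl ether stays fixed. Both groups count 6 heavy atoms, so the heavy-atom count alone does not separate them, and nothing measured in this set gives a cause for the step.

Among the compounds shown here, the single pair leaves open which part of the change carries the step: the loss of the five-membered aromatic ring, the arrival of the amide hydrogen, or the isopropyl group on the amide nitrogen. Also open, as far as these compounds go, is where a dimethylcarbamoyl group, a nitrile, a carboxylic acid or an unsubstituted carbamoyl group at this place would fall relative to compound 3 and compound 4, and whether a 1,3,4-oxadiazole would hold the number of compound 3.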